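Shortening the dialkylamino group: compound 3 to compound 4

A few compounds are considered here, and "the series" means these few. Any claim that something is new, unique, unknown or untested is made for them only; others in the source may bear on it.

Measured so far, with the structures and values:
Compound 1, `CCCCN(CC)c1nc(C)nc2c(-c3ccc(OC)nc3C)c(C)nn12`, gives 4.9 nM in an assay on cell membranes for displacement of a labelled ligand from corticotropin-releasing factor receptor 1 (Rattus norvegicus); on this read-out lower numbers stand for stronger inhibition and higher numbers for weaker inhibition.
Compound 2, `CCCCC(C)Nc1nc(C)nc2c(-c3ccc(OC)nc3C)c(C)nn12`, gives 5.1 nM in this assay.
Compound 3, `CCCN(CCC)c1nc(C)nc2c(-c3ccc(OC)nc3C)c(C)nn12`, gives 5.7 nM in this assay.

Compound 3 has the highest of the three numbers, but the steps leading to it, a 1.2-fold higher number from compound 1 to compound 3 (0.07 log units; within the scatter) and a 1.1-fold higher number from compound 2 to compound 3 (0.05 log units; within the scatter), are both within the scatter, so the three compounds are not separated in this assay.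

Compound 4, `CCN(CC)c1nc(C)nc2c(-c3ccc(OC)nc3C)c(C)nn12`, is not yet measured. The change from compound 3 is diethylamino in place of dipropylamino on an aromatic carbon. All three measured steps exchange one dialkylamino group for another on the same carbon, and none moves beyond the scatter: a 1.0-fold higher number from compound 1 to compound 2 (0.02 log units; within the scatter), a 1.2-fold higher number from compound 1 to compound 3 (0.07 log units; within the scatter), a 1.1-fold higher number from compound 2 to compound 3 (0.05 log units; within the scatter). None of them, however, shortens the group on both chains at once, so the present change is only indirectly covered.

The number for compound 4 in this assay is therefore expected to stay close to that of compound 3, the estimated step being a 1.4-fold higher number from compound 3 to compound 4 (0.15 log units; within the scatter), with a slightly higher number allowed for the smaller group. Compound 4 is estimated at 8 nM, in a range from 3 nM to 25 nM.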

Compound 4, half-maximal inhibitory concentration: 12 nM
Compound 4: middle estimate off by 1.5-fold (0.18 log units), on the low side, within the range that was stated.
By their numbers in this assay, from the lowest: compounds 1, 2 and 3 (each within the scatter of the next); then compound 4.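

In this assay, the amino group on this aromatic carbon is not freely interchangeable: diethylamino separates from all three larger groups (a 2.1-fold higher number from compound 3 to compound 4 (0.32 log units; beyond the scatter)) (a 2.4-fold higher number from compound 2 to compound 4 (0.37 log units; beyond the scatter)) (a 2.4-fold higher number from compound 1 to compound 4 (0.39 log units; beyond the scatter)). These steps are modest, yet they leave compound 4 with the highest number of the four, so the flat response across dipropylamino, butyl(ethyl)amino and (1-methylpentyl)amino does not carry over unchanged to diethylamino. No supporting data are available to explain this shift.

Going by these compounds, whether dimethylamino would raise the number further, or dibutylamino would stay level with compound 3, remains open. With only four compounds, all sharing one core, it is also unknown whether the same step would hold with a different group elsewhere on that core.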